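A few compounds are considered here, and "the series" means these few. Any claim that something is new, unique, unknown or untested is made for them only; others in the source may bear on it.

Compound 1 `COc1ccc(Nc2ncc3ccc(-c4ccccc4OC)n3n2)cc1` in an in vitro ADME assay on microsomes from liver (Rattus norvegicus, strain Sprague-Dawley) for metabolic stability, using NADPH, with a stated time of 10 min, tested at 0.5 uM (a lower number here means that the compound disappears faster, a higher number that the compound lasts longer), gives 0.117 h.
Compound 2 `COc1ccccc1-c1ccc2cnc(Nc3ccc(S(=O)(=O)N(C)C)cc3)nn12` in this assay gives 0.0833 h.

Compound 2 has the lower of the two numbers, though its gap to compound 1 is within the scatter. Compound 3 `COc1ccccc1-c1ccc2cnc(Nc3ccc(N4CCN(C[C@H](C)O)CC4)cc3)nn12` differs from compound 2 in one place: 4-(2-hydroxypropyl)piperazin-1-yl in place of dimethylsulfamoyl on an aromatic carbon. Among the measured compounds shown here, the only measured step that bears on this position is a 1.4-fold lower number from compound 1 to compound 2 (0.15 log units; within the scatter), which did not exceed the scatter. With no other comparison to draw on, the step of a 1.0-fold lower number from compound 2 to compound 3 (0.02 log units; within the scatter) is expected to stay within the scatter. Compound 3 is therefore estimated to give 0.08 h in this assay, within a range of 0.03 h to 0.22 h.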

Compound 3, half-life: 0.6 h
Compound 3: middle estimate off by 7.5-fold (0.88 log units), on the low side, outside the stated range (above it).
By their numbers in this assay, from the lowest: compounds 2 and 1 (each within the scatter of the next); then compound 3.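

At this position the read-out can move beyond the scatter: in this assay, 4-(2-hydroxypropyl)piperazin-1-yl in place of dimethylsulfamoyl gives a 7.2-fold higher number from compound 2 to compound 3 (0.86 log units; beyond the scatter), and in place of methoxy it gives a 5.1-fold higher number from compound 1 to compound 3 (0.71 log units; beyond the scatter). Among the compounds shown here, the earlier change between methoxy and dimethylsulfamoyl had stayed within the scatter, so only this larger group, with its non-aromatic ring and hydroxyl-bearing chain, separates one compound from the others. Nothing available explains the rise. The compounds shown leave open which part of the group matters. An unsubstituted piperazine or a morpholine at this position could separate the ring from the 2-hydroxypropyl chain, and the opposite stereoisomer could test the stereocentre.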